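This account rests on a few compounds, and the source may have more. Where it says the series, first, only, none or still open, it means among the compounds named here.

Measured compounds:
Compound 1 `COc1ccc(-c2ccc3c(c2)C(=O)C(=O)N3C)cc1` gives 4980 nM in a functional assay on K562 cells (Homo sapiens) for antiproliferative activity, read by MTT assay, with a stated time of 48 h; a higher number here means a weaker inhibitor, a lower number a stronger inhibitor.
Compound 2 `C=CCN1C(=O)C(=O)c2cc(-c3ccc(OC)cc3)ccc21` gives 390 nM in this assay.
Compound 3 `COc1ccc(-c2ccc3c(c2)C(=O)C(=O)N3Cc2ccc(OC)c(OC)c2)cc1` gives 60 nM in this assay.

Of these three numbers, compound 1 stands highest: its nearest neighbour is compound 2, at a 13-fold lower number from compound 1 to compound 2 (1.11 log units; beyond the scatter), and the furthest is compound 3, at an 83-fold lower number from compound 1 to compound 3 (1.92 log units; beyond the scatter). Compound 4 `COc1ccc(-c2ccc3c(c2)C(=O)C(=O)N3Cc2ccc3ccccc3c2)cc1` differs from compound 1 in one place: naphthalen-2-yl in place of hydrogen on a saturated chain carbon bound to an amide-type nitrogen in a ring.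

Among the compounds with values here, two measured steps bear directly on this change, since both replace the same hydrogen on the saturated chain carbon bound to the amide-type nitrogen in the ring. Replacing it with vinyl gave a 13-fold lower number from compound 1 to compound 2 (1.11 log units; beyond the scatter); replacing it with 3,4-dimethoxyphenyl gave an 83-fold lower number from compound 1 to compound 3 (1.92 log units; beyond the scatter). Between those two, a 6.5-fold lower number from compound 2 to compound 3 (0.81 log units; beyond the scatter) shows that the aromatic ring at this place gives the lower number. Naphthalen-2-yl is, like 3,4-dimethoxyphenyl, an aromatic group entering at this place, so a large downward step in this assay is expected, of the order seen for compound 3. The estimate for compound 4 is 80 nM, in the range 20 nM to 320 nM, corresponding to the expected step of a 62-fold lower number from compound 1 to compound 4 (1.79 log units; beyond the scatter).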

Compound 4, half-maximal inhibitory concentration: 400 nM
The estimate for compound 4 lay 5.0-fold (0.70 log units) below the measured number; measured number outside the range, above it.
By their numbers in this assay, from the lowest: compound 3; then compounds 2 and 4 (each within the scatter of the next); then compound 1.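

At the saturated chain carbon bound to the amide-type nitrogen in a ring, naphthalen-2-yl still lowers the number in this assay (a 12-fold lower number from compound 1 to compound 4 (1.10 log units; beyond the scatter)), but this step resembles the vinyl step (a 13-fold lower number from compound 1 to compound 2 (1.11 log units; beyond the scatter)) more than the 3,4-dimethoxyphenyl step. An aromatic group at this place is therefore not enough on its own to match compound 3 (a 6.7-fold higher number from compound 3 to compound 4 (0.82 log units; beyond the scatter)), and naphthalen-2-yl does not separate from vinyl (a 1.0-fold higher number from compound 2 to compound 4 (0.01 log units; within the scatter)). Compound 4 thus goes against any reading that aromatic groups as such give the lowest number here, and no evidence is available to explain the difference.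

Going by these compounds, what a plain phenyl, a phenyl with one methoxy group or an amine-bearing chain would give at this place remains open. So does whether the methoxy groups of compound 3 or its aromatic ring account for its low number.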